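The compounds below may be only part of what the source reports. "The series", "measured", "known", "first", "only" and "open" are said of these compounds alone.

Working notes on the cinnamic acid triazole series.

The measured reference point is compound 1 `COc1ccc(/C=C\C(=O)O)c(OCc2cn(-c3ccc(NC(C)=O)cc3)nn2)c1CC=C(C)C`. In a functional assay on COLO 205 cells (Homo sapiens) for cytotoxicity, read by MTT assay, with a stated time of 24 h (a higher number here means a weaker inhibitor, a lower number a stronger inhibitor), compound 1 gives 22600 nM, so the series sits at weak inhibition on this read-out. Compound 2 `COc1cccc(-n2cc(COc3c(/C=C\C(=O)O)ccc(OC)c3CC=C(C)C)nn2)c1`, the 3-methoxyphenyl analogue, in this assay is recorded as "not determined" (no result reported): no result was reported, so compound 2 cannot be placed on the scale beyond sharing the core of compound 1.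

The step considered here is from compound 2 to compound 3 `COc1ccc(/C=C\C(=O)O)c(OCc2cn(-c3cccc(C#N)c3)nn2)c1CC=C(C)C`. The structural change is cyano in place of methoxy on an aromatic carbon, in words a cyano in place of methoxy on an aromatic carbon. Among the compounds with values here, no step between two measured compounds is available to calibrate this exchange. With only compound 1 as an anchor, the expectation is that the exchange moves the half-maximal inhibitory concentration by no more than the usual scatter of this assay , in no preferred direction, and that compound 3 stays in the weak range set by compound 1 in this assay .

Compound 3 is therefore estimated at 25000 nM, with a range from 8000 nM to 80000 nM.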

Compound 3, half-maximal inhibitory concentration: 26800 nM
Compound 3: middle estimate off by 1.1-fold (0.03 log units), on the low side, within the range that was stated.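

In this assay, within the data shown here, 3-cyanophenyl in place of 4-acetamidophenyl on an aromatic nitrogen gives a 1.2-fold higher number from compound 1 to compound 3 (0.07 log units; within the scatter) and provides the first measured comparison at this position. Two aryl groups that differ in both the substituent and its place on the phenyl group therefore leave the series in the same weak range, so this position shows no sensitivity across this one pair, while the exchange of methoxy for cyano itself cannot be read, as compound 2 has no reported result. No supporting measurement bears on this result.

Going by these compounds, whether an amine, a trifluoromethyl group or a carboxylic acid on the phenyl group would keep the number in this range remains open, and a single pair cannot separate the contribution of the substituent from that of its place. Also open, on these data alone, is whether a methyl ester in place of the carboxylic acid of the shared core would move the series out of the weak range that compound 1 and compound 3 occupy.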